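Aryl ester variation and cytotoxicity in the flavone series

This account rests on a few compounds, and the source may have more. Where it says the series, first, only, none or still open, it means among the compounds named here.

Measured in an ADME assay on cells (T-cell, Mus musculus, strain BALB/c) for cytotoxicity, read by MTT assay, with a stated time of 48 h; on this read-out higher numbers stand for lower toxicity in this test and lower numbers for higher toxicity in this test:

compound 1 `COC(=O)c1ccc(Cl)cc1OC(=O)COc1cc(O)c2c(=O)cc(-c3ccccc3)oc2c1`: 265000 nM
compound 2 `COC(=O)c1cccc(Cl)c1OC(=O)COc1cc(O)c2c(=O)cc(-c3ccccc3)oc2c1`: 366000 nM
compound 3 `COC(=O)c1ccccc1OC(=O)COc1cc(O)c2c(=O)cc(-c3ccccc3)oc2c1`: 265000 nM

All three numbers sit close together. Compound 1 stands level with compound 3 at the digits shown, the two together the lowest of the three values, and its furthest neighbour is compound 2 with a 1.4-fold higher number from compound 1 to compound 2 (0.14 log units; within the scatter). The two other steps, no change at the digits printed from compound 1 to compound 3 (within the scatter) and a 1.4-fold lower number from compound 2 to compound 3 (0.14 log units; within the scatter), are likewise within the scatter, so exchanging one chloro-(methoxycarbonyl)phenyl ester for another, or removing the chloro altogether, has left the read-out unmoved.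

Compound 4 `COC(=O)c1cc(Br)ccc1OC(=O)COc1cc(O)c2c(=O)cc(-c3ccccc3)oc2c1` is the next member. It differs from compound 1 as follows:

4-bromo-2-(methoxycarbonyl)phenyl in place of 5-chloro-2-(methoxycarbonyl)phenyl on an oxygen next to a carbonyl group

Among the compounds with values here, the steps that bear on this are the exchange of the whole aryl ester group between compound 1 and compound 2 and the loss of chloro between compound 1 and compound 3, both within the scatter. A single bromine standing where a chlorine stood on the same kind of ester group is a change of comparable scale, and no step beyond the scatter is expected in this assay. For compound 4 the estimate is 280000 nM, in the range 150000 nM to 520000 nM, which is an expected 1.1-fold higher number from compound 1 to compound 4 (0.02 log units; within the scatter).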

Compound 4, half-maximal cytotoxic concentration: > 450000 nM
Compound 4: only a limit was reported (the forecaster's own chance of this, stated with the estimate: 10%); at least 1.6-fold (0.20 log units) between middle value and limit.
By their numbers in this assay, from the lowest: compounds 1, 3 and 2 (each within the scatter of the next). At a limit, above all of these: compound 4.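

In this assay the reading for compound 4 is a limit and not a number: the limit of > 450000 nM in this assay, at which 1 of the 4 values shown sits. Only floors can therefore be stated, namely an at least 1.6-fold higher number from compound 1 to compound 4 (0.22 log units; that floor lies within the scatter), an at least 1.6-fold higher number from compound 3 to compound 4 (0.22 log units; that floor lies within the scatter) and an at least 1.2-fold higher number from compound 2 to compound 4 (0.08 log units; that floor lies within the scatter), and with each floor inside the scatter, none of these steps establishes a real change, though the true gaps may be larger. Within the data shown here, what is new for this place, on an oxygen next to a carbonyl group, is that 4-bromo-2-(methoxycarbonyl)phenyl gives the first reading at a limit, with no sign of higher toxicity in this test than for the two chloro esters or the ester without halogen.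

On these data alone, compound 1 and compound 4 differ in both the halogen and its place on the ring, as the names 5-chloro and 4-bromo show, so the two changes cannot be separated, and how far compound 4 truly lies from its limit also remains unknown. As far as these compounds go, whether a carboxylic acid in place of the methoxycarbonyl group, or an amine in place of the halogen, would move the read-out beyond the scatter stays open.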